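Chloroquinoline triazole series: benzyl to benzimidazolylmethyl

The compounds below may be only part of what the source reports. "The series", "measured", "known", "first", "only" and "open" are said of these compounds alone.

Measured compounds:
compound 1, `CN(CCNCc1cn(Cc2ccccc2)nn1)CCNc1ccnc2cc(Cl)ccc12`, 32000 nM
compound 2, `CN(CCNCc1cn(Cc2ccc(Br)cc2)nn1)CCNc1ccnc2cc(Cl)ccc12`, 12000 nM

In a functional assay on NCI-H460 cells (Homo sapiens) for antiproliferative activity, read by sulforhodamine B assay, with a stated time of 72 h (on this read-out lower numbers stand for stronger inhibition and higher numbers for weaker inhibition), compound 2 gives the lowest of the two numbers, with a 2.7-fold lower number from compound 1 to compound 2 (0.43 log units; beyond the scatter) setting it apart from compound 1. Compound 3, `CN(CCNCc1cn(Cc2nc3cc(Cl)ccc3[nH]2)nn1)CCNc1ccnc2cc(Cl)ccc12`, is not yet measured. The change is 5-chloro-1H-benzimidazol-2-yl in place of 4-bromophenyl on a saturated chain carbon bound to an aromatic nitrogen. Within the data shown here, no measured step covers this exchange; the only step known, from compound 1 to compound 2, concerns a single halogen on the ring that now leaves entirely, so it gives no direct guide. A step of about a 1.2-fold lower number from compound 2 to compound 3 (0.08 log units; within the scatter) is expected, with the direction open. Compound 3 is estimated at 10000 nM, within 3000 nM to 40000 nM.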

Compound 3, half-maximal inhibitory concentration: 59000 nM
The estimate for compound 3 lay 5.9-fold (0.77 log units) below the measured number; the measured number lies above the stated range.
By their numbers in this assay, from the lowest: compound 2; then compounds 1 and 3 (each within the scatter of the next).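

In this assay, the gain seen with the 4-bromobenzyl group does not carry over to (5-chloro-1H-benzimidazol-2-yl)methyl, with a 4.9-fold higher number from compound 2 to compound 3 (0.69 log units; beyond the scatter) on this exchange. Set against the plain benzyl group, the same ring gives a 1.8-fold higher number from compound 1 to compound 3 (0.27 log units; within the scatter), so the exchange from phenyl leaves the number within the usual scatter. Nothing available explains the result.

Open, from the compounds shown here alone, is whether the chlorine on the benzimidazole plays any part in this number. Also open, going by these compounds, is how an amine or a carboxylic acid would read in place of the bromo on the benzyl ring.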